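Fluorinated stilbenes as activators of nuclear factor erythroid 2-related factor 2

The source may hold more compounds than are shown below. What is called first, only, known or untested is meant among the compounds shown, and "the series" means these compounds.

Measured compounds:
compound 1 `Fc1ccccc1/C=C/c1ccccc1F`: 4300 nM
compound 2 `Fc1ccccc1/C=C/c1c(F)cccc1F`: 1400 nM
compound 3 `Fc1ccc(/C=C/c2cccc(F)c2)cc1`: 650 nM

The three compounds were run in an assay on HepG2 cells for activation of nuclear factor erythroid 2-related factor 2 (Homo sapiens), read by a luciferase reporter, with a stated time of 5 h; a lower number here means that less compound is needed, a higher number that more compound is needed for the effect. Compound 1 gives 4300 nM there. Adding a fluoro in place of hydrogen on an aromatic carbon to reach compound 2 gives a 3.1-fold lower number from compound 1 to compound 2 (0.49 log units; beyond the scatter). Compound 3 is built from the same atoms as compound 1 joined differently; in this assay compound 3 gives 650 nM, the lowest of the three numbers, and the difference between the two cores is not broken down here.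

Compound 4 `Fc1cccc(/C=C/c2ccc(F)cc2F)c1` has not yet been measured. It is related to compound 3 by fluoro in place of hydrogen on an aromatic carbon, which is the same change that carries compound 1 to compound 2; the two place descriptions agree word for word. That earlier step is the only measured instance of this change among the compounds shown, so the expectation for compound 4 rests on it alone, together with the value of compound 3. The expected step is a 2.2-fold lower number from compound 3 to compound 4 (0.34 log units; beyond the scatter), set somewhat smaller than the earlier one because a 3.1-fold lower number from compound 1 to compound 2 (0.49 log units; beyond the scatter) rests on a single pair and repeated measurements scatter. Compound 4 is therefore estimated at 300 nM in this assay, with a likely range from 120 nM to 800 nM.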

Compound 4, half-maximal effective concentration: 450 nM
The estimate for compound 4 lay 1.5-fold (0.18 log units) below the measured number; low and high end bracket the measured number.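

In this assay, fluoro in place of hydrogen on an aromatic carbon gives a 1.4-fold lower number from compound 3 to compound 4 (0.16 log units; within the scatter), so on this core the change does not stand out from repeat measurement. The step on this core and the earlier step cannot be told apart, so the data give no sign that the two cores respond differently to the change: the same change on two cores in this assay, a 3.1-fold lower number (0.49 log units; beyond the scatter) from compound 1 to compound 2 and a 1.4-fold lower number (0.16 log units; within the scatter) from compound 3 to compound 4, 2.1-fold (0.33 log units) apart, within the scatter of two such steps

This does not show that the change transfers reliably, since two pairs are too few to set a rule for the series, and they leave undecided whether the drop seen on the core of compound 1 also occurs to a smaller degree on the core of compound 3.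

The compounds shown carry only fluoro and hydrogen on their aromatic rings, which leaves open how a chloro, a methoxy group, a hydroxyl, an amine or a carboxylic acid would read at the same place in this assay. Also open, on these data alone, is how far the place of a fluoro group on a ring, rather than the core that carries it, decides the size of the step, which one pair on each core cannot separate.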